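A few compounds are considered here, and "the series" means these few. Any claim that something is new, unique, unknown or untested is made for them only; others in the source may bear on it.

Measured compounds in a functional assay on PANC-1 cells (Homo sapiens) for inhibition, read by MTT assay, with a stated time of 72 h; on this read-out higher numbers stand for weaker inhibition of growth and lower numbers for stronger inhibition of growth:
- compound 1 `O=S(=O)(NCCCNCc1ccc(Cl)cc1)c1cc(C(F)(F)F)cc(C(F)(F)F)c1` gives 4900 nM
- compound 2 `COc1cccc(CNCCCNS(=O)(=O)c2cc(C(F)(F)F)cc(C(F)(F)F)c2)c1` gives 10000 nM
- compound 3 `CN(CCCNS(=O)(=O)c1cc(C(F)(F)F)cc(C(F)(F)F)c1)Cc1ccccc1` sits at the limit of the assay, > 50000 nM, which is a limit and not a number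

Compound 3 therefore stands at the weak end of the three measured compounds, with only a limit known, as the limit of > 50000 nM in this assay, at which 1 of the 3 values shown sits, records. The measured steps leading to it are an at least 10-fold higher number from compound 1 to compound 3 (1.00 log units; beyond the scatter) and an at least 5.0-fold higher number from compound 2 to compound 3 (0.69 log units; beyond the scatter), both beyond the scatter and both running in the direction of weaker inhibition.

Compound 4 `COc1ccccc1CNCCCNS(=O)(=O)c1cc(C(F)(F)F)cc(C(F)(F)F)c1` is unmeasured. It differs from compound 3 by (2-methoxybenzyl)amino in place of benzyl(methyl)amino on a saturated chain carbon, three bonds along the chain from a sulfonamide nitrogen. This change reverses the kind of move seen in the steps from compound 1 and from compound 2 to compound 3: a (methoxybenzyl)amino group with its hydrogen-bond donor enters where benzyl(methyl)amino leaves. Compound 1 and compound 2 differ from each other by a 2.0-fold higher number from compound 1 to compound 2 (0.31 log units; beyond the scatter), a modest step, so the substituent on the benzyl ring matters less than the amine pattern here. The step for compound 4 is expected to be an at least 7.1-fold lower number from compound 3 to compound 4 (0.85 log units; beyond the scatter), toward stronger inhibition. The value of compound 4 in this assay is estimated at 7000 nM, with a range from 2500 nM to 25000 nM.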

Compound 4, concentration for 50% growth inhibition: 12000 nM
Compound 4: middle estimate off by 1.7-fold (0.23 log units), on the low side; low and high end bracket the measured number.
By their numbers in this assay, from the lowest: compound 1; then compounds 2 and 4 (each within the scatter of the next). At a limit, above all of these: compound 3.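

In this assay, the (2-methoxybenzyl)amino group gives an at least 4.1-fold lower number from compound 3 to compound 4 (0.61 log units; beyond the scatter), so a third ring-substituted benzylamine with a hydrogen-bond donor on the amine reads as a number, unlike the benzyl(methyl)amino compound. The placing of the methoxy group makes little difference here, with 2-methoxyphenyl for 3-methoxyphenyl giving a 1.2-fold higher number from compound 2 to compound 4 (0.08 log units; within the scatter), while 2-methoxyphenyl for 4-chlorophenyl gives a 2.4-fold higher number from compound 1 to compound 4 (0.39 log units; beyond the scatter). Compound 3 remains a limit and not a number: the limit of > 50000 nM in this assay, at which 1 of the 4 values shown sits.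

Every step to compound 3 changes the ring substituent and the amine methyl together, so the contribution of each stays unresolved. From the compounds shown here alone, a plain benzylamino group and a (2-methoxybenzyl)(methyl)amino group would separate the two, and the effect of a longer chain between the two nitrogens also stays open.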